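Swapping a urea for a chlorinated benzamide: expected tolerance

The compounds below may be only part of what the source reports. "The series", "measured", "known", "first", "only" and "open" are said of these compounds alone.

Measured so far:
Compound 1 `COc1cc(-c2nn(-c3cccc(NC(=O)c4cccc(C(F)(F)F)c4)c3)cc2-c2ccncc2)ccc1Cl` — > 50000 nM
Compound 2 `COc1cc(-c2nn(-c3cccc(NC(=O)Nc4cccc(C(F)(F)F)c4)c3)cc2-c2ccncc2)ccc1Cl` — 50000 nM

Within the data shown here, in a functional assay on BT-549 cells (Homo sapiens) for inhibition, read by sulforhodamine B assay, with a stated time of 48 h (a higher number here means that more compound is tolerated, a lower number that less compound is tolerated), compound 2 gives 50000 nM, the only plain number among the two values shown. Compound 1 reaches only the assay limit, (the limit of > 50000 nM in this assay, at which 1 of the 2 values shown sits). The step of a number no higher from compound 1 to compound 2 (the limit leaves the size open) cannot be sized. Compound 3 `COc1cc(-c2nn(-c3cccc(NC(=O)c4ccc(Cl)c(C(F)(F)F)c4)c3)cc2-c2ccncc2)ccc1Cl` carries 4-chloro-3-(trifluoromethyl)phenyl in place of (3-(trifluoromethyl)phenyl)amino on a carbonyl carbon. That change reverses the measured step and goes further, so compound 3 is expected to return to the limit region rather than move. The expected step is no change at the digits printed from compound 2 to compound 3 (within the scatter). Compound 3 is expected to give 50000 nM, ranging from 20000 nM to 150000 nM.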

Compound 3, concentration lethal to 50% of the cells: > 32500 nM
Compound 3: a limit, no number; the forecaster's own chance of this, stated with the estimate: 60%; the middle value lies beyond the limit too.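

Compound 3 gives only a limit, so neither its step from compound 1 nor its step from compound 2 can be read. As far as these compounds go, whether chloro in place of hydrogen shifts the value in this assay stays open.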